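The source may hold more compounds than are shown below. What is called first, only, known or untested is meant among the compounds shown, and "the series" means these compounds.

Compound 1 `CC[C@@H](NC(=O)CC(C)C)C(=O)N1CCC(c2ccc(Cl)cc2)CC1` and compound 2 `CC(C)CC(=O)N[C@@H](C(=O)N1CCC(c2ccc(Cl)cc2)CC1)C(C)C` share one core and differ in a single place: methyl in place of hydrogen on a saturated chain carbon bound to two saturated chain carbons. In an assay on THP-1 cells for displacement of a labelled ligand from C-C chemokine receptor type 1 (Homo sapiens) (on this read-out lower numbers stand for stronger inhibition and higher numbers for weaker inhibition), compound 1 gives 152 nM, while compound 2 gives 32 nM, a step of a 4.8-fold lower number from compound 1 to compound 2 (0.68 log units; beyond the scatter). Compound 3 `CCCC(NC(=O)c1ccccc1C)C(=O)N1CCC(c2ccc(Cl)cc2)CC1` rests on a core whose difference from the core of compound 1 is not broken down here; in this assay compound 3 gives 152 nM, level with compound 1. Compound 4 `Cc1ccccc1C(=O)NC(CC(C)C)C(=O)N1CCC(c2ccc(Cl)cc2)CC1` has not yet been measured. It differs from compound 3 by methyl in place of hydrogen on a saturated chain carbon bound to two saturated chain carbons, the same change as that made from compound 1 to compound 2, although here the same difference cut one bond further out reads propyl to isobutyl, where before it read ethyl to isopropyl. The expectation for compound 4 in this assay rests on the step of a 4.8-fold lower number from compound 1 to compound 2 (0.68 log units; beyond the scatter) and on the value of compound 3, 152 nM. Since that earlier step was made on another core and on a shorter chain, its full size is not taken over. For compound 4 a smaller step is expected, a 2.3-fold lower number from compound 3 to compound 4 (0.37 log units; beyond the scatter). Compound 4 is estimated at 65 nM, between 25 nM and 160 nM.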

Compound 4, half-maximal inhibitory concentration: 88 nM
For compound 4 the middle estimate is 1.4-fold (0.13 log units) below the measured one, and the stated range covers the measured number.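

Within the data shown here, on the core of compound 3, the same methyl gives a 1.7-fold lower number from compound 3 to compound 4 (0.24 log units; within the scatter) in this assay, a step too small to be told apart from no step at all. Set beside the earlier step, which read ethyl to isopropyl where this one reads propyl to isobutyl, it shows that the size of this change did not carry over from one core to the other: the same change on two cores in this assay, a 4.8-fold lower number (0.68 log units; beyond the scatter) from compound 1 to compound 2 and a 1.7-fold lower number (0.24 log units; within the scatter) from compound 3 to compound 4, 2.8-fold (0.44 log units) apart, beyond the scatter of two such steps

This does not show that the methyl has no effect on the second core, and two pairs of compounds give neither a reason for the gap nor a rule for any further core.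

The compounds shown leave open how a group other than methyl would behave on a saturated chain carbon bound to two saturated chain carbons, such as a longer chain, an amine or a carboxylic acid. They also leave open whether the step on a third core would resemble the larger step or the smaller one.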